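The source may report more compounds than this note shows. Statements on the series, on what has been measured and on what is new or still open speak of the compounds shown alone.

Measured so far:
- compound 1 `C[C@@H](NC(=O)Nc1ccc(C(C)(C)C)cc1)c1ccccc1` gives 88%
- compound 2 `C[C@H](NC(=O)Nc1ccc(C(C)(C)C)cc1)c1ccccc1` gives 88%
- compound 3 `C[C@@H](NC(=O)Nc1ccc(C(F)(F)F)cc1)c1ccccc1` gives 89%

In an ADME assay on the whole organism with Oryza sativa as the target, tested at 1 uM (on this read-out higher numbers stand for a weaker effect at the one concentration tested and lower numbers for a stronger effect), compound 2 stands level with compound 1 at the digits shown, the two together the lowest of the three numbers, with compound 3 the furthest away. The step of no change at the digits printed from compound 1 to compound 2 (within the scatter) rests only on (the fact that compounds 1 and 2 differ only in the configuration as drawn). The step of a number 1 percentage points higher from compound 1 to compound 3 (within the scatter) replaces the same tert-butyl that is now in question. Compound 4 `C[C@H](NC(=O)Nc1ccc(F)cc1)c1ccccc1` differs from compound 2 as follows: fluoro in place of tert-butyl on an aromatic carbon. Among the measured compounds shown here, since the only comparable step, from compound 1 to compound 3, stayed within the scatter, no step beyond the scatter is expected here either. Compound 4 is therefore expected to give 88%, between 78% and 96%, a step of no change at the digits printed from compound 2 to compound 4 (within the scatter).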

Compound 4, a percentage reported as activity, at one concentration (the size of the read-out at that concentration, not a potency): 97%
Compound 4: middle estimate off by 9 percentage points, on the low side; the whole stated range lies below it.
By their numbers in this assay, from the lowest: compounds 1, 2, 3 and 4 (each within the scatter of the next).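

In this assay, the change from tert-butyl, with its 4 heavy atoms, to fluoro, with 1, at this place on the aromatic ring gives a number 9 percentage points higher from compound 2 to compound 4 (within the scatter). So even this large cut in the group's size is not separated from compound 2 by the read-out, and nothing at hand bears on why the number came out as it did. As far as these compounds go, whether an amine or a carboxylic acid on this aromatic carbon would move the number beyond the scatter stays open, as does the effect of a longer chain there.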